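The compounds below may be only part of what the source reports. "The series", "measured", "known", "first", "only" and "open" are said of these compounds alone.

In a functional assay on SH-SY5Y cells (Homo sapiens) for antiproliferative activity, read by MTT assay, with a stated time of 48 h (a higher number here means a weaker inhibitor of growth, a lower number a stronger inhibitor of growth), compound 1 (`COc1ccc(N(C)c2nc(Cl)nc3c2ncn3Cc2cc(OC)cc(OC)c2)cc1`) gives > 100000 nM, which is a limit and not a number. Compound 2 (`COc1cc(Cn2cnc3c(Cl)ncnc32)cc(OC)c1`) gives > 100000 nM, also a limit. Going by the values given here, compound 2 therefore stands with compound 1 at the limit of > 100000 nM in this assay, at which 2 of the 2 values shown sit, and no measured step is available to size a change. Compound 3 (`COc1cc(Cn2cnc3c(Cl)nc(Cl)nc32)cc(OC)c1`) carries chloro in place of hydrogen on an aromatic carbon between two ring nitrogen atoms: chloro in place of hydrogen on an aromatic carbon. A modest expected shift toward stronger inhibition of growth in this assay, an at least 1.6-fold lower number from compound 2 to compound 3 (0.22 log units; that floor lies within the scatter), may not clear the limit. Compound 3 is estimated at 60000 nM, with an expected range of 15000 nM to 150000 nM.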

Compound 3, concentration for 50% growth inhibition: 1700 nM
Estimate against measurement, compound 3: 35-fold (1.55 log units) above; measured number below the stated range.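

Chloro on the aromatic carbon between two ring nitrogen atoms turns an inactive compound into a measurable inhibitor of growth in this assay: an at least 58-fold lower number from compound 2 to compound 3 (1.76 log units; beyond the scatter). Chloro in place of (4-methoxyphenyl)(methyl)amino on an aromatic carbon gives an at least 58-fold lower number from compound 1 to compound 3 (1.76 log units; beyond the scatter), so among these three compounds only the one carrying both chloro groups registers. Both steps are floors and not sizes, as each starts from a limit: the limit of > 100000 nM in this assay, at which 2 of the 3 values shown sit.

Going by these compounds, whether bromo, methoxy or an amine on the carbon between two ring nitrogen atoms would hold this activity stays open. So does whether a smaller group such as dimethylamino could replace the other chloro.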